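Swapping anilino for 4-methylpiperazin-1-yl in compound 1

The source may report more compounds than this note shows. Statements on the series, on what has been measured and on what is new or still open speak of the compounds shown alone.

compound 1 `Nc1ccccc1NC(=O)c1ccc(Cn2cnc3c(Nc4ccccc4)nc(Cl)nc32)cc1` gives 2920 nM
compound 2 `CC(C)n1cnc2c(NCc3ccc(C(=O)Nc4ccccc4N)cc3)nc(Cl)nc21` gives 2130 nM
compound 3 `Nc1ccccc1NC(=O)c1ccc(COCNc2nc(Nc3ccccc3)c3ncn(C4CCCC4)c3n2)cc1` gives 8700 nM

In a functional assay on HeLa cells (Homo sapiens) for antiproliferative activity, read by CCK-8 assay, with a stated time of 72 h (a lower number here means a stronger inhibitor, a higher number a weaker inhibitor), compound 1 matches compound 2 within the scatter, while compound 3 gives a higher number, beyond the scatter. The next compound, still unmeasured, is compound 4 `CN1CCN(c2nc(Cl)nc3c2ncn3Cc2ccc(C(=O)Nc3ccccc3N)cc2)CC1` with 4-methylpiperazin-1-yl in place of anilino on an aromatic carbon and the rest of compound 1 unchanged. For the measured compounds named here, no measured pair shows this swap, so the data offer no direct guide. The expected step of a 1.2-fold higher number from compound 1 to compound 4 (0.08 log units; within the scatter) is small, toward a higher number and within the scatter. Compound 4 is estimated at 3500 nM with an expected range from 1200 nM to 10000 nM on repeat measurement.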

Compound 4, half-maximal inhibitory concentration: 1170 nM
For compound 4 the middle estimate is 3.0-fold (0.48 log units) above the measured one; measured number outside the range, below it.
By their numbers in this assay, from the lowest: compounds 4, 2 and 1 (each within the scatter of the next, the first and the last beyond it); then compound 3.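

In this assay, putting 4-methylpiperazin-1-yl in place of anilino on this aromatic carbon gives a 2.5-fold lower number from compound 1 to compound 4 (0.40 log units; beyond the scatter) and so counts as a modest gain. The position therefore accepts a non-aromatic ring with 2 hetero atoms in place of an all-carbon aromatic ring, and activity survives the loss of the anilino hydrogen-bond donor. No measurement here explains the gain.

Going by these compounds, whether the methyl group or the second ring nitrogen matters stays open. An unsubstituted piperazine or a morpholine ring, with oxygen in place of that nitrogen, would separate the two.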